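The source may hold more compounds than are shown below. What is called first, only, known or untested is meant among the compounds shown, and "the series" means these compounds.

Measured so far:
- compound 1 `CN(CC1=CC[C@H]2C[C@@H]1C2(C)C)Cc1ccc(Br)cc1`: 3160 nM
- compound 2 `COC(=O)c1cccc(-c2ccc(CN(C)CC3=CC[C@H]4C[C@@H]3C4(C)C)cc2)c1`: > 316 nM

In an assay on HEK293 cells for displacement of a labelled ligand from C-X-C chemokine receptor type 3 (Homo sapiens) (on this read-out higher numbers stand for weaker inhibition and lower numbers for stronger inhibition), compound 1 gives 3160 nM. For compound 2 the assay returned only a limit, > 316 nM, and no number. Among the compounds with values here, compound 2 thus stands without a fixed place among the values shown, and no measured step links it to any other compound.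

Compound 3 `CN(CC1=CC[C@H]2C[C@@H]1C2(C)C)Cc1ccc(-c2cccc(O)c2)cc1` differs from compound 2 in one place: hydroxy in place of methoxycarbonyl on an aromatic carbon, meta to a large group. Within the data shown here, no measured pair shows this change, so there is no ground for expecting a step beyond the usual scatter in either direction. With compound 2 given only as a limit, the step from compound 2 to compound 3 is expected to be small, at a step that the limit leaves unreadable from compound 2 to compound 3. Compound 3 is therefore estimated at 1500 nM, with a range from 300 nM to 8000 nM, and a fair chance that it too returns only a limit.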

Compound 3, inhibition constant: > 316 nM
Compound 3: a limit, no number (the forecaster's own chance of this, stated with the estimate: 40%); the middle value does not contradict the limit.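

Compound 3 returns only a limit, so no step from compound 1 or compound 2 to compound 3 can be read, because the read-out stops at the same limit for both: the limit of > 316 nM in this assay, at which 2 of the 3 values shown sit.

The compounds shown leave open where compound 2 and compound 3 actually lie, and whether hydroxy and methoxycarbonyl differ at all.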